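Benzoyl to Acetyl on Two Thiourea Cores

This account rests on a few compounds, and the source may have more. Where it says the series, first, only, none or still open, it means among the compounds named here.

Measured compounds:
- compound 1 `O=C(NC(=S)Nc1ccc(Oc2ccccc2)cc1)c1ccccc1` gives 2100 nM
- compound 2 `CC(=O)NC(=S)Nc1ccc(Oc2ccccc2)cc1` gives 3700 nM
- compound 3 `CCOc1ccc(OCC)c(NC(=S)NC(=O)c2ccccc2)c1` gives 2040 nM

These three compounds were tested in an assay for inhibition of epoxide hydrolase 1 (Homo sapiens), read by fluorescence, using microsomes; on this read-out higher numbers stand for weaker inhibition and lower numbers for stronger inhibition. Compound 1 and compound 2 share a core and differ in one place: methyl in place of phenyl on a carbonyl carbon. That change made a 1.8-fold higher number from compound 1 to compound 2 (0.25 log units; within the scatter), so the two compounds are not separated by this assay.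

Compound 3 carries a different core, and how the core of compound 3 differs from the core of compound 1 is not broken down here. Compound 4 `CCOc1ccc(OCC)c(NC(=S)NC(C)=O)c1` has not yet been measured in this assay. It stands to compound 3 as compound 2 stands to compound 1: methyl in place of phenyl on a carbonyl carbon. The place of the change is described in the same words for both pairs, so it is the same change made a second time.

Going by the values given here, the expectation for compound 4 rests on compound 1 and compound 2, because a 1.8-fold higher number from compound 1 to compound 2 (0.25 log units; within the scatter) is the only record of this change. Compound 4 is therefore expected to give 3700 nM, within 1800 nM to 7500 nM. The expected step is a 1.8-fold higher number from compound 3 to compound 4 (0.26 log units; within the scatter), a step of the same modest size as the earlier one.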

Compound 4, half-maximal inhibitory concentration: 2530 nM
Compound 4: middle estimate off by 1.5-fold (0.17 log units), on the high side; measured number inside the range.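

In this assay, the benzoyl to acetyl change on the core of compound 3 gave a 1.2-fold higher number from compound 3 to compound 4 (0.09 log units; within the scatter), so this pair is not separated by the assay, just as the pair on the core of compound 1 was not. This shows only that methyl in place of phenyl on a carbonyl carbon left the number within the scatter on both cores; with just two pairs, it does not show that the change has a real effect of any size, or that the same would hold on a third core. The two steps can nonetheless be read as agreeing, which is what supports carrying the change from one of these cores to the other: the same change on two cores in this assay, a 1.8-fold higher number (0.25 log units; within the scatter) from compound 1 to compound 2 and a 1.2-fold higher number (0.09 log units; within the scatter) from compound 3 to compound 4, 1.4-fold (0.15 log units) apart, within the scatter of two such steps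

The compounds shown leave open whether any other group on this carbonyl carbon, such as a longer chain, a cyclohexyl ring or an amine, would give a step beyond the scatter. They also leave open how a carboxylic acid on the phenyl of the benzoyl group would read in this assay on either core.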